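The source may report more compounds than this note shows. Statements on the series, on what has been measured and on what is new or still open speak of the compounds shown alone.

In an ADME assay on L929 cells (Mus musculus) for cytotoxicity, read by resazurin assay, with a stated time of 48 h (on this read-out lower numbers stand for higher toxicity in this test and higher numbers for lower toxicity in this test), compound 1 `C=Cn1c2ccc([N+](=O)[O-])cc2c(=O)n1Cc1ccccc1` gives 160000 nM. Compound 2 `O=C(O)CCCn1c2ccc([N+](=O)[O-])cc2c(=O)n1Cc1ccccc1` gives only a limit of the test, > 256000 nM. Compound 3 `NC(=O)CCCn1c2ccc([N+](=O)[O-])cc2c(=O)n1Cc1ccccc1` likewise gives only a limit, > 256000 nM.

Compound 1 thus holds the only number shown; the other two values sit at the limit of > 256000 nM in this assay, at which 2 of the 3 values shown sit. Compound 4 `O=c1c2cc([N+](=O)[O-])ccc2n(CCO)n1Cc1ccccc1` differs from compound 1 in one place: 2-hydroxyethyl in place of vinyl on an aromatic nitrogen. Two measured steps change the same vinyl on the same aromatic nitrogen, an at least 1.6-fold higher number from compound 1 to compound 2 (0.20 log units; that floor lies within the scatter) and an at least 1.6-fold higher number from compound 1 to compound 3 (0.20 log units; that floor lies within the scatter), and both floors lie within the scatter. For compound 4 a similar outcome is expected, a small rise or none beyond the scatter, a 1.4-fold higher number from compound 1 to compound 4 (0.14 log units; within the scatter). Compound 4 is therefore estimated at 220000 nM, in the range 110000 nM to 400000 nM.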

Compound 4, concentration lethal to 50% of the cells: > 256000 nM
Compound 4 was reported as a limit; the forecaster's own chance of this, stated with the estimate: 45%; middle value at least 1.1-fold (0.06 log units) from the limit.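

In this assay, putting 2-hydroxyethyl in place of vinyl on this aromatic nitrogen gives an at least 1.6-fold higher number from compound 1 to compound 4 (0.20 log units; that floor lies within the scatter). A chain ending in hydroxy therefore gives the same kind of result as the chains ending in a carboxylic acid or an amide, with a floor that shows no change beyond the scatter. The steps among compounds 2, 3 and 4 cannot be read, since all three values are limits: the limit of > 256000 nM in this assay, at which 3 of the 4 values shown sit.

Whether a real rise lies behind these limits stays open. So does the result for a chain ending in an amine, or for a plain ethyl group, on the same nitrogen.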